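Benzyl sulfanyl for sulfonyl swap: solubility notes

The compounds below may be only part of what the source reports. "The series", "measured", "known", "first", "only" and "open" are said of these compounds alone.

Compound 2 `O=C(O)c1ccc(C(=O)/C(=C\c2ccc(F)c([N+](=O)[O-])c2)S(=O)(=O)Cc2ccc(Br)cc2)cc1` is the reference point. In a physicochemical assay for solubility (a lower number here means a less soluble compound, a higher number a more soluble compound), compound 2 gives < 1000 ug/mL, which is a limit of the assay rather than a number. Compound 1 `O=C(O)c1ccc(C(=O)/C(=C\c2ccc(F)c([N+](=O)[O-])c2)SCc2ccc(Cl)cc2Cl)cc1` differs from it by (2,4-dichlorobenzyl)sulfanyl in place of (4-bromobenzyl)sulfonyl on a double-bonded chain carbon bound to a carbonyl carbon and a double-bonded chain carbon. In this assay compound 1 gives < 1000 ug/mL, again only a limit. The step that the two limits leave unreadable from compound 2 to compound 1 therefore cannot be sized. Compound 3 `O=C(O)c1ccc(C(=O)/C(=C\c2ccc(Cl)c([N+](=O)[O-])c2)S(=O)(=O)Cc2ccc(Br)cc2)cc1` differs from compound 2 in its core by chloro in place of fluoro on an aromatic carbon. In this assay compound 3 gives < 1000 ug/mL, once more a limit. The step that the two limits leave unreadable from compound 2 to compound 3 is likewise unreadable. What the data show is the limit of < 1000 ug/mL in this assay, at which 3 of the 3 values shown sit.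

Compound 4 `O=C(O)c1ccc(C(=O)/C(=C\c2ccc(Cl)c([N+](=O)[O-])c2)SCc2ccc(Cl)cc2Cl)cc1` is not yet measured; it differs from compound 3 by (2,4-dichlorobenzyl)sulfanyl in place of (4-bromobenzyl)sulfonyl on a double-bonded chain carbon bound to a carbonyl carbon and a double-bonded chain carbon, the same change as from compound 2 to compound 1, at the same place. For compound 4 the step is expected to be a step that the limit leaves unreadable from compound 3 to compound 4, an expectation that rests only on the limit of < 1000 ug/mL in this assay, at which 3 of the 3 values shown sit, and is unreadable in size. Compound 4 is therefore estimated at 300 ug/mL, with a range from 30 ug/mL to 1000 ug/mL, and most likely the assay will again report only a limit.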

Compound 4, solubility: < 1000 ug/mL
Compound 4: no number, only a limit; the forecaster's own chance of this, stated with the estimate: 85%; the middle value is on the limit's open side.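

No new step can be read: compound 4 gives only a limit, so its comparisons with compound 3 and compound 1 cannot be sized. The compounds shown leave open where any of them truly stands in this assay, and whether either change shifts the read-out at all, with the whole set resting on one value: the limit of < 1000 ug/mL in this assay, at which 4 of the 4 values shown sit.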